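The source may report more compounds than this note shows. Statements on the series, on what has been measured and on what is new or still open speak of the compounds shown alone.

Measured compounds in the series:

- compound 1, `CC(C)[C@H](C[C@H]1CCNC1=O)c1ccc(-c2ccc3cccc(F)c3c2)[nH]c1=O` — 26800 nM
- compound 2, `CC(C)C(Cc1nnn[nH]1)c1ccc(-c2ccc3cccc(F)c3c2)[nH]c1=O` — 27300 nM

Both numbers come from a physicochemical assay for solubility, in phosphate buffer, measured as kinetic solubility; on this read-out higher numbers stand for higher solubility and lower numbers for lower solubility. Compound 1 gives 26800 nM and compound 2 gives 27300 nM; the two values sit within the usual scatter of each other, so nothing separates them on this read-out. Going by the values given here, no step between two measured compounds differing in a single place has been recorded, so the series so far offers no measured size of effect for any one change.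

Compound 3, `CC(C)[C@@H](C[C@H]1CCNC1=O)c1ccc(-c2ccc3cccc(F)c3c2)[nH]c1=O`, is not yet measured. Its relation to compound 1 is as follows: the two compounds have the same atoms and bonds and differ only in configuration as drawn: 1 of 2 stereo elements differ; a stereocentre at a saturated chain carbon is drawn S in compound 1 and R in compound 3. Since only a drawn configuration at one saturated chain carbon changes and the atoms and bonds stay the same, no step beyond the scatter is expected from compound 1 to compound 3 in this assay, in either direction; a 1.0-fold higher number from compound 1 to compound 3 (0.00 log units; within the scatter) is the expected step. Among the compounds with values here, the estimate for compound 3 in this assay is 27000 nM, with a range from 12000 nM to 60000 nM, the range kept wide to cover the scatter of kinetic solubility measurements with no measured stereochemical step to anchor it.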

Compound 3, solubility: 32000 nM
Estimate against measurement, compound 3: 1.2-fold (0.07 log units) below; the measured number falls inside the stated range.
By their numbers in this assay, from the lowest: compounds 1, 2 and 3 (each within the scatter of the next).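

In this assay the series now has its first measured step between compounds that differ in one place, a 1.2-fold higher number from compound 1 to compound 3 (0.08 log units; within the scatter). The earlier pair could not give this reading, as compound 1 and compound 2 differ in more than one feature, whereas this comparison isolates the drawn configuration at a single saturated chain carbon and finds that S and R are not separated on this read-out, a finding that holds for this pair and this stereocentre only. The step can be assigned to that one place: the fact that compounds 1 and 3 differ only in the configuration as drawn

The compounds shown leave open whether the second stereo element, drawn alike in compound 1 and compound 3, has any measurable step of its own in this assay. Also open, going by these compounds, is whether a change of atoms rather than of configuration, such as a carboxylic acid, an amine or a longer chain on this saturated chain carbon, would give a step beyond the scatter.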